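The source may report more compounds than this note shows. Statements on the series, on what has been measured and on what is new or still open speak of the compounds shown alone.

Compound 1, with structure `COc1ccc(Nc2nc3c(Cl)ncnc3s2)cc1`, is the starting point. In an assay on CHO cells for displacement of a labelled ligand from adenosine receptor A1 (Homo sapiens), read by scintillation counting, with a stated time of 3 h (on this read-out higher numbers stand for weaker inhibition and lower numbers for stronger inhibition), compound 1 gives 11500 nM, and this is the only outright number available among the two measured compounds, so compound 1 stands alone on the numbers shown.

Compound 2, with structure `Clc1ccc(Nc2nc3c(N4CCCC4)ncnc3s2)cc1`, is the other measured compound. In this assay compound 2 gives > 100000 nM, which is a limit of the assay and not a number. In this connection the limit of > 100000 nM in this assay, at which 1 of the 2 values shown sits, describes where that value sits. Within the data shown here, compound 2 differs from compound 1 in more than one place, so no single step between them can be read off.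

Compound 3, with structure `Clc1ncnc2sc(Nc3ccccc3)nc12`, is not yet measured. It differs from compound 1 by hydrogen in place of methoxy on an aromatic carbon. Among the measured compounds shown here, no measured step matches this change, so the expectation is a step in this assay that stays within the usual scatter, with no clear direction. The expected step from compound 1 to compound 3 is a 1.0-fold higher number from compound 1 to compound 3 (0.02 log units; within the scatter). Compound 3 is therefore estimated at 12000 nM, with a range from 4000 nM to 40000 nM.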

Compound 3, inhibition constant: > 100000 nM
Compound 3 ended at the assay's limit; the forecaster's own chance of this, stated with the estimate: 10%; middle value at least 8.3-fold (0.92 log units) away from the limit.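

Among these compounds, replacing methoxy with hydrogen gives the first step that can be read in this set: in this assay, the change produces an at least 8.6-fold higher number from compound 1 to compound 3 (0.93 log units; beyond the scatter). Compound 3 gives > 100000 nM, which is a limit of the assay and not a number, and the set now stands as follows: the limit of > 100000 nM in this assay, at which 2 of the 3 values shown sit. Among the compounds shown here, the methoxy group, on an aromatic carbon of a six-membered aromatic ring of carbon only and para to a large group, is the one difference between compound 1, which has a measurable value, and compound 3, which does not, although these data do not show which property of the group matters.

The compounds shown leave open whether another group at this place, such as an ethoxy group, a hydroxyl group or an amine, would behave like methoxy or like hydrogen, since only those two are compared here. For the compounds shown here, compound 2 differs from compound 1 in more than one place, so no step involving it can be read, and what each of its changes does alone remains unknown.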